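This account rests on a few compounds, and the source may have more. Where it says the series, first, only, none or still open, it means among the compounds named here.

Measured compounds:
- compound 1 `O=C1COc2ccc(NC(=O)C3CCN(c4ccccc4Br)CC3)cc2N1` — 71 nM
- compound 2 `O=C1COc2ccc(NC(=O)C3CCN(c4ccccc4Cl)CC3)cc2N1` — 93 nM
- compound 3 `Cc1cccc(N2CCC(C(=O)Nc3ccc4c(c3)NC(=O)CO4)CC2)c1C` — 28 nM

All three share one core and differ only in the aryl group on the amine nitrogen in the ring. In an assay on HEK293 cells for displacement of a labelled ligand from transient receptor potential cation channel subfamily V member 1 (Homo sapiens) (a lower number here means a stronger inhibitor, a higher number a weaker inhibitor), compound 3 stands lowest of the three numbers, and both of its steps are beyond the scatter: a 2.5-fold lower number from compound 1 to compound 3 (0.40 log units; beyond the scatter) and a 3.3-fold lower number from compound 2 to compound 3 (0.52 log units; beyond the scatter). Between compound 1 and compound 2 the step is within the scatter: a 1.3-fold higher number from compound 1 to compound 2 (0.12 log units; within the scatter).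

Compound 4 `CC(C)c1ccccc1N1CCC(C(=O)Nc2ccc3c(c2)NC(=O)CO3)CC1` is not yet measured. Its change from compound 3 is 2-isopropylphenyl in place of 2,3-dimethylphenyl on an amine nitrogen in a ring. The two measured steps that bear on it, from compound 1 and from compound 2 to compound 3, both exchange the aryl group at the same place and both move the number only modestly. Going by the values given here, no measured pair shows the 2-isopropylphenyl group itself, so its direction is open. On that basis a step near or just beyond the scatter is expected, with weakening somewhat more likely than gain: a 1.6-fold higher number from compound 3 to compound 4 (0.21 log units; within the scatter). Compound 4 is therefore estimated at 45 nM, with a range from 15 nM to 130 nM.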

Compound 4, inhibition constant: 78 nM
Compound 4: the middle estimate sits 1.7-fold (0.24 log units) below what was measured; the range from low to high includes it.
By their numbers in this assay, from the lowest: compound 3; then compounds 1, 4 and 2 (each within the scatter of the next).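

In this assay, the advantage seen with 2,3-dimethylphenyl on the amine nitrogen in the ring does not extend to 2-isopropylphenyl: a 2.8-fold higher number from compound 3 to compound 4 (0.44 log units; beyond the scatter). The halogen comparisons give a 1.2-fold lower number from compound 2 to compound 4 (0.08 log units; within the scatter) and a 1.1-fold higher number from compound 1 to compound 4 (0.04 log units; within the scatter), so isopropyl cannot be separated from chloro or bromo on the aromatic carbon, and among these four compounds only compound 3 stands apart. No supporting measurement accompanies these values, and the reason for this pattern remains unexplained.

The compounds shown leave open whether a phenyl group carrying a single methyl would match compound 3 at this position. As far as these compounds go, it is also open whether a methoxyphenyl or trifluoromethylphenyl group here would separate from the halogen-bearing and isopropyl-bearing compounds.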